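Trifluoromethyl for tert-butyl on the benzyl ring

The source may hold more compounds than are shown below. What is called first, only, known or untested is meant among the compounds shown, and "the series" means these compounds.

Measured compounds:
compound 1 `O=S(=O)(NCCNCc1ccc(-c2ccccc2)cc1)c1cc(C(F)(F)F)cc(C(F)(F)F)c1` gives 4200 nM in a functional assay on PANC-1 cells (Homo sapiens) for inhibition, read by MTT assay, with a stated time of 72 h; a higher number here means a weaker inhibitor of growth, a lower number a stronger inhibitor of growth
compound 2 `CC(C)(C)c1ccc(CNCCCNS(=O)(=O)c2cc(C(F)(F)F)cc(C(F)(F)F)c2)cc1` gives 2500 nM in this assay

Of the compounds shown here, two have been measured in this assay. Compound 2 has the lower of the two numbers, but the gap to compound 1 is within the scatter of this kind of measurement, so nothing separates them with confidence. Compound 3 `O=S(=O)(NCCCNCc1ccc(C(F)(F)F)cc1)c1cc(C(F)(F)F)cc(C(F)(F)F)c1` has not yet been measured. It differs from compound 2 in one place: trifluoromethyl in place of tert-butyl on an aromatic carbon. Within the data shown here, no measured pair shows the effect of this change, so the expectation rests only on the two values at hand and on the size of the change, which keeps the count of heavy atoms and of donors and acceptors the same. A step from compound 2 to compound 3 of a 1.2-fold higher number from compound 2 to compound 3 (0.08 log units; within the scatter) is expected, meaning no change beyond the scatter in either direction. Compound 3 is therefore estimated at 3000 nM in this assay, with a range from 1200 nM to 8000 nM.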

Compound 3, concentration for 50% growth inhibition: 3200 nM
Estimate against measurement, compound 3: 1.1-fold (0.03 log units) below; low and high end bracket the measured number.
By their numbers in this assay, from the lowest: compounds 2, 3 and 1 (each within the scatter of the next).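

Among these compounds, this is the first pair in this assay that differs in one place only, and it isolates the exchange of tert-butyl for trifluoromethyl on an aromatic carbon, with a 1.3-fold higher number from compound 2 to compound 3 (0.11 log units; within the scatter). On this one background, the two groups cannot be told apart, so replacing four carbon atoms with one carbon and three fluorine atoms at this position leaves the number within the scatter. A single pair cannot show whether the same would hold with another chain or another benzyl substituent.

The compounds shown leave open whether a methoxy group, a carboxylic acid or a plain hydrogen on this aromatic carbon would move the number beyond the scatter. No measurement is at hand that could explain why this exchange makes no visible difference.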